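The source may report more compounds than this note shows. Statements on the series, on what has been measured and on what is new or still open speak of the compounds shown alone.

In an ADME assay on LLC-MK2 cells (Macaca mulatta) for cytotoxicity, read by spectrophotometry and crystal violet staining, with a stated time of 4 days (a lower number here means that less compound is tolerated, a higher number that more compound is tolerated), compound 1 `CC(C)n1ncc2c(C(=O)Nc3cncnc3)cc(-c3cccs3)nc21` gives 20000 nM. Compound 2 `CC(C)n1ncc2c(C(=O)Nc3c(F)cc(F)cc3F)cc(-c3cccs3)nc21` gives > 200000 nM, which is a limit of the assay and not a number. Compound 2 therefore has no exact position on the scale: the limit of > 200000 nM in this assay, at which 1 of the 2 values shown sits. For the measured compounds named here, the one measured step is an at least 10-fold higher number from compound 1 to compound 2 (1.00 log units; beyond the scatter), with 2,4,6-trifluorophenyl in place of pyrimidin-5-yl on an amide-type nitrogen.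

Compound 3 `CC(C)n1ncc2c(C(=O)Nc3cccc(F)c3F)cc(-c3cccs3)nc21` carries 2,3-difluorophenyl in place of 2,4,6-trifluorophenyl at that same amide-type nitrogen: 2,3-difluorophenyl in place of 2,4,6-trifluorophenyl on an amide-type nitrogen. This change stays within carbon-only aromatic rings, so it does not reverse the measured step, and the pyrimidin-5-yl of compound 1 does not return. Going by the values given here, that step, an at least 10-fold higher number from compound 1 to compound 2 (1.00 log units; beyond the scatter), is the only guide, and its full size is unknown. It gives no direct measure of the swap from one fluorinated phenyl to another. A large fall toward compound 1 is therefore not expected, and only a modest move to lower numbers, or none beyond the scatter, is anticipated in this assay. The expected change is an at least 1.3-fold lower number from compound 2 to compound 3 (0.12 log units; that floor lies within the scatter), read against a limit. The estimated value for compound 3 is 150000 nM, expected within 50000 nM to 200000 nM.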

Compound 3, half-maximal cytotoxic concentration: 75000 nM
Compound 3: the middle estimate sits 2.0-fold (0.30 log units) above what was measured, and the stated range covers the measured number.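

In this assay, the replacement of 2,4,6-trifluorophenyl by 2,3-difluorophenyl on an amide-type nitrogen gives an at least 2.6-fold lower number from compound 2 to compound 3 (0.42 log units; beyond the scatter), so this site responds to a change between two fluorinated, carbon-only aromatic rings and not only to the swap away from pyrimidin-5-yl. Compound 3 also retains a clear difference from the pyrimidin-5-yl compound, with a 3.8-fold higher number from compound 1 to compound 3 (0.57 log units; beyond the scatter), and both fluorinated phenyl compounds shown therefore give higher numbers than compound 1. The value of compound 2 is a limit of the assay and not a number, so the true size of the step to compound 3 stays unknown and only its floor can be read: the limit of > 200000 nM in this assay, at which 1 of the 3 values shown sits.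

Compound 2 and compound 3 differ both in the count of fluorine atoms and in their pattern on the ring, and the two effects cannot be separated with these compounds. Also open, going by these compounds, is how this assay would respond at the same amide-type nitrogen to an unsubstituted phenyl, or to a phenyl carrying an amine or a carboxylic acid.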